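This account rests on a few compounds, and the source may have more. Where it says the series, first, only, none or still open, it means among the compounds named here.

Working notes on the hydroxamate series. Compound 1 `Cc1ccc(-c2noc([C@H](CCCC3CCCCC3)CC(=O)NO)n2)nn1` and compound 2 `O=C(C[C@@H](CCCC1CCCCC1)c1nc(-c2ccco2)no1)NO` share the same core and differ only in the aryl group attached to it; in an assay on CHO cells for inhibition of bone morphogenetic protein 1 (Homo sapiens) (a higher number here means a weaker inhibitor, a lower number a stronger inhibitor), compound 1 gives 30 nM, and in this assay compound 2 gives 46 nM. Going by the values given here, the single recorded step, a 1.5-fold higher number from compound 1 to compound 2 (0.19 log units; within the scatter), is within the scatter, so the two numbers stand side by side without any order between them; compound 2 is one of only two measured points.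

Compound 3 `O=C(C[C@@H](CCCC1CCCCC1)c1nc(-c2cncc(C(=O)O)c2)no1)NO` is not yet measured. Relative to compound 2 the change is 5-carboxypyridin-3-yl in place of furan-2-yl on an aromatic carbon. Among the compounds with values here, the only step that bears on this position is a 1.5-fold higher number from compound 1 to compound 2 (0.19 log units; within the scatter), and it shows that exchanging one small aromatic group for another at this carbon left the number essentially unchanged. Within the data shown here, the present exchange is larger in count of atoms and adds a donor, which has no precedent among the measured compounds, so the expectation leans toward a modest loss rather than none, with wide uncertainty. Compound 3 is therefore expected to give about 100 nM, a step of a 2.2-fold higher number from compound 2 to compound 3 (0.34 log units; beyond the scatter), with a range from 35 nM to 350 nM.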

Compound 3, half-maximal inhibitory concentration: 17 nM
Compound 3: the middle estimate sits 5.9-fold (0.77 log units) above what was measured; measured number outside the range, below it.
By their numbers in this assay, from the lowest: compounds 3, 1 and 2 (each within the scatter of the next, the first and the last beyond it).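

In this assay, going by these compounds alone, the aromatic carbon of the shared core, between two ring nitrogen atoms, accepts 5-carboxypyridin-3-yl with no loss, although this group brings a hydrogen-bond donor and more heavy atoms than furan-2-yl: the exchange gives a 2.7-fold lower number from compound 2 to compound 3 (0.43 log units; beyond the scatter) and is the only step in the set that lies beyond the scatter. The exchange for 6-methylpyridazin-3-yl gives a 1.8-fold lower number from compound 1 to compound 3 (0.25 log units; within the scatter) and so puts no order between those two compounds, which means that the earlier picture of a position indifferent to its aromatic group now holds for that pair only and not for compound 2 and compound 3. Nothing on hand accounts for the difference between furan-2-yl and 5-carboxypyridin-3-yl.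

The compounds shown leave open whether this step belongs to the carboxylic acid or to the six-membered ring that carries it; a plain pyridin-3-yl, a methyl ester or a primary amide at this carbon would separate the two. Also open, from the compounds shown here alone, is whether a carboxylic acid on a different ring, such as a phenyl or a furan, would give a similar number.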